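Aryl substituent variation on the shared core

The source may hold more compounds than are shown below. What is called first, only, known or untested is meant among the compounds shown, and "the series" means these compounds.

Measured compounds:
compound 1, `CC#CC(CC(=O)O)c1ccc(OCc2ccc3nc(-c4ccc(C(F)(F)F)cc4)cn3c2)cc1`, 558 nM in an assay on isolated protein for agonist activity at Free fatty acid receptor 1 (Homo sapiens); a lower number here means that less compound is needed, a higher number that more compound is needed for the effect
compound 2, `CC#CC(CC(=O)O)c1ccc(OCc2ccn3cc(-c4ccc(C5CCCCC5)cc4)nc3c2)cc1`, 559 nM
compound 3, `CC#CC(CC(=O)O)c1ccc(OCc2ccc3nc(-c4ccccc4C)cn3c2)cc1`, 389 nM

Compound 2 has the highest of the three numbers in this assay, but its gaps to compound 1 and to compound 3 both lie within the scatter, so no order among the three can be read. For the measured compounds named here, the only measured step, a 1.4-fold lower number from compound 1 to compound 3 (0.16 log units; within the scatter), exchanges the substituent on the pendant phenyl ring and stays within the scatter.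

Compound 4, `CC#CC(CC(=O)O)c1ccc(OCc2ccn3cc(-c4ccc(C(C)C)cc4)nc3c2)cc1`, is not yet measured. It differs from compound 2 by isopropyl in place of cyclohexyl on an aromatic carbon. Going by the values given here, no measured step addresses this exchange; the one step available concerns a different substituent and a different pattern on the pendant ring, and it was small. On that basis compound 4 is expected to stay close to compound 2, with the step of a 1.2-fold higher number from compound 2 to compound 4 (0.07 log units; within the scatter) expected to lie within the scatter. Compound 4 is estimated at 650 nM in this assay, with a range from 300 nM to 1400 nM.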

Compound 4, half-maximal effective concentration: 615 nM
Beside the measured number, compound 4's estimate is 1.1-fold (0.02 log units) above it; the range from low to high includes it.
By their numbers in this assay, from the lowest: compounds 3, 1, 2 and 4 (each within the scatter of the next).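

Isopropyl in place of cyclohexyl on this aromatic carbon, para to a large group, gives a 1.1-fold higher number from compound 2 to compound 4 (0.04 log units; within the scatter) in this assay and is the only measured exchange at this place on the core of compound 2. Within these two compounds, the six-membered carbon ring can therefore be replaced by an open group with fewer heavy atoms without a change that can be read. Nothing at hand explains this result.

On these data alone, whether this place also accepts a group that brings in hydrogen-bond donors or acceptors, such as an amine or a carboxylic acid, or a longer chain such as n-hexyl, remains open. Also open, as far as these compounds go, is whether the same exchange would give a similar result on the core of compound 1.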